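A few compounds are considered here, and "the series" means these few. Any claim that something is new, unique, unknown or untested is made for them only; others in the source may bear on it.

Working notes on the series. In a functional assay on LNCaP cells (Homo sapiens) for antiproliferative activity, read by propidium iodide staining, with a stated time of 96 h (on this read-out higher numbers stand for weaker inhibition and lower numbers for stronger inhibition), compound 1 `CC(O)(CSc1ccc(F)cc1)C(=O)Nc1ccc(S(F)(F)(F)(F)F)cc1` gives 12500 nM and compound 2 `CC(O)(COc1ccc(OC(F)(F)F)cc1)C(=O)Nc1ccc(S(F)(F)(F)(F)F)cc1` gives 18600 nM, so compound 2 stands within the scatter of compound 1. The next analogue, compound 3 `CC(O)(COc1ccc(C#N)cc1)C(=O)Nc1ccc(S(F)(F)(F)(F)F)cc1`, has cyano in place of trifluoromethoxy on an aromatic carbon, para to a large group: cyano in place of trifluoromethoxy on an aromatic carbon. Among the compounds with values here, no step between measured compounds is available to size this change, so no shift beyond the scatter is expected in this assay. The estimated step of a 1.2-fold lower number from compound 2 to compound 3 (0.07 log units; within the scatter) reflects this. For compound 3 the expected value is 16000 nM, with an estimated range of 7000 nM to 40000 nM.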

Compound 3, half-maximal inhibitory concentration: 100000 nM
For compound 3 the middle estimate is 6.3-fold (0.80 log units) below the measured one; the measured number lies above the stated range.
By their numbers in this assay, from the lowest: compounds 1 and 2 (each within the scatter of the next); then compound 3.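

In this assay the aromatic carbon para to a large group proves sensitive to its substituent: cyano in place of trifluoromethoxy gives a 5.4-fold higher number from compound 2 to compound 3 (0.73 log units; beyond the scatter), a step beyond the scatter. 4-Cyanophenoxy in place of (4-fluorophenyl)sulfanyl on a saturated chain carbon gives an 8.0-fold higher number from compound 1 to compound 3 (0.90 log units; beyond the scatter), which sets compound 3 apart from compound 1 and compound 2. No accompanying measurement accounts for these steps. The compounds shown leave open how an amine or a carboxylic acid on this aromatic carbon would read.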